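Isopropyl in Place of Phenyl: an Estimate for Compound 4

The source may hold more compounds than are shown below. What is called first, only, known or untested is meant among the compounds shown, and "the series" means these compounds.

Compound 1, `CCC(C)C(NC(=O)NO)C(=O)NC1CCCCC1`: 89000 nM
Compound 2, `O=C1NC(c2ccccc2)C(=O)N1C1CCCC1`: > 200000 nM
Compound 3, `CCC(C)C(NC(=O)NO)C(=O)NC1CCCC1`: > 100000 nM

All three were tested in a functional assay on L1210 cells (Mus musculus) for inhibition; a lower number here means a stronger inhibitor, a higher number a weaker inhibitor. Compound 1 gives a number in this assay, 89000 nM. For compound 3 the result is a limit of the assay rather than a number, > 100000 nM, as recorded in the limit of > 100000 nM in this assay, at which 1 of the 3 values shown sits. Compound 2 also stands at a limit, > 200000 nM, as recorded in the limit of > 200000 nM in this assay, at which 1 of the 3 values shown sits; it is the weakest result shown only in the sense that no number was reached.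

For the measured compounds named here, the single measured step, an at least 1.1-fold higher number from compound 1 to compound 3 (0.05 log units; that floor lies within the scatter), concerns cyclopentyl in place of cyclohexyl on an amide-type nitrogen, a different place and different groups; it does not bear on the change to compound 4.

Compound 4, `CC(C)C1NC(=O)N(C2CCCC2)C1=O`, differs from compound 2 by isopropyl in place of phenyl on a saturated ring carbon. Going by the values given here, no measured step covers this change, so the expectation rests on compound 2 alone. The step that the limit leaves unreadable from compound 2 to compound 4 is expected to stay within the scatter. Compound 4 is therefore estimated at 300000 nM, with a range from 100000 nM to 1000000 nM, most likely again reported only as a limit.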

Compound 4, half-maximal inhibitory concentration: > 200000 nM
Compound 4: no number, only a limit (the forecaster's own chance of this, stated with the estimate: 80%); the middle value is on the limit's open side.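

Compound 2 and compound 4 both give only a limit, not a number, so no step can be read between them for isopropyl in place of phenyl: the limit of > 200000 nM in this assay, at which 2 of the 4 values shown sit. The compounds shown leave open how strongly either compound inhibits, and whether these two groups differ at all.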